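Changing the aryl group on a shared core

A few compounds are considered here, and "the series" means these few. Any claim that something is new, unique, unknown or untested is made for them only; others in the source may bear on it.

Compound 1 `Cn1cc(-c2cccc(C(C)(C)O)c2)c2cc(C(=O)NCc3ccc(C(=O)Nc4ccccc4N)cc3)[nH]c2c1=O`: 2200 nM
Compound 2 `Cc1ccccc1-c1cn(C)c(=O)c2[nH]c(C(=O)NCc3ccc(C(=O)Nc4ccccc4N)cc3)cc12`: 310 nM

Among the compounds with values here, in a functional assay on MV4-11 cells (Homo sapiens) for antiproliferative activity, read by CCK-8 assay, with a stated time of 72 h (on this read-out lower numbers stand for stronger inhibition and higher numbers for weaker inhibition), compound 2 gives 310 nM, the lower of the two numbers measured so far. Compound 3 `Cn1cc(-c2ccc(F)cc2)c2cc(C(=O)NCc3ccc(C(=O)Nc4ccccc4N)cc3)[nH]c2c1=O` has not yet been measured. It differs from compound 2 in one place: 4-fluorophenyl in place of 2-methylphenyl on an aromatic carbon. In words, 4-fluorophenyl stands in place of 2-methylphenyl on an aromatic carbon.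

Within the data shown here, only one measured step bears on this change. With 2-methylphenyl in place of 3-(1-hydroxy-1-methylethyl)phenyl on an aromatic carbon, the step is a 7.1-fold lower number from compound 1 to compound 2 (0.85 log units; beyond the scatter). This modest step lies beyond the scatter and shows that a change of this group can move the number. Among the measured compounds shown here, no measured compound carries 4-fluorophenyl, so the data do not fix the direction. For the measured compounds named here, compound 2 holds the lower of only two values, so a small rise seems the likelier outcome, though a fall cannot be excluded. The expected step is a 1.9-fold higher number from compound 2 to compound 3 (0.29 log units; within the scatter), smaller than the measured one. For compound 3 the estimated value is 600 nM, with an expected range from 170 nM to 2000 nM.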

Compound 3, half-maximal inhibitory concentration: 220 nM
For compound 3 the middle estimate is 2.7-fold (0.44 log units) above the measured one; measured number inside the range.
By their numbers in this assay, from the lowest: compounds 3 and 2 (each within the scatter of the next); then compound 1.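

a 1.4-fold lower number from compound 2 to compound 3 (0.15 log units; within the scatter) in this assay lies within the scatter, so at this aromatic carbon 4-fluorophenyl and 2-methylphenyl cannot be told apart, although one carries fluorine and the other a methyl group. a 10-fold lower number from compound 1 to compound 3 (1.00 log units; beyond the scatter) lies beyond the scatter and, read with a 7.1-fold lower number from compound 1 to compound 2 (0.85 log units; beyond the scatter), shows that two different aryl groups each give a clearly lower number than 3-(1-hydroxy-1-methylethyl)phenyl, so the earlier single step was not particular to 2-methylphenyl. No measurement on these compounds gives a cause for the higher number seen with 3-(1-hydroxy-1-methylethyl)phenyl.

The compounds shown leave open whether that higher number follows from the 1-hydroxy-1-methylethyl group itself or from where it stands on the phenyl ring, as this group appears in only one compound. They also leave open how an unsubstituted phenyl, a phenyl ring carrying an amine or a carboxylic acid, or a simple methyl group in place of the aryl ring would read at this carbon.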